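Swapping one aryl group in a cytotoxicity test

The source may report more compounds than this note shows. Statements on the series, on what has been measured and on what is new or still open speak of the compounds shown alone.

In a toxicity assay on MT4 cells (Homo sapiens) for cytotoxicity, read by MTT assay (a lower number here means that less compound is tolerated, a higher number that more compound is tolerated), compound 1 `Cc1cc(-c2ccc(C#N)c(C#N)c2)ccc1Oc1cc(N)nc(Nc2ccc(C#N)cc2)n1` gives 76700 nM and compound 2 `COc1cc(-c2ccc(C#N)cc2)ccc1Oc1cc(N)nc(Nc2ccc(C#N)cc2)n1` gives 120000 nM. Compound 3 `Cc1cc(-c2cccc(F)c2)cc(C)c1Oc1cc(N)nc(Nc2ccc(C#N)cc2)n1` stands lowest of the three at 24700 nM, beyond the usual scatter from both others, so it is the least tolerated so far. Compound 4 `Cc1cc(-c2ccc(Cl)cc2)cc(C)c1Oc1cc(N)nc(Nc2ccc(C#N)cc2)n1` differs from compound 3 in one place, with 4-chlorophenyl in place of 3-fluorophenyl on an aromatic carbon. Within the data shown here, no measured pair isolates a change like this one. Compound 3, at 24700 nM, is the nearest measured structure, so compound 4 is expected to sit close to it. The estimated change is a 1.2-fold lower number from compound 3 to compound 4 (0.09 log units; within the scatter), which is not expected to exceed the scatter. For compound 4 the estimated value is 20000 nM, with an expected range of 7000 nM to 60000 nM.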

Compound 4, half-maximal cytotoxic concentration: 21500 nM
The estimate for compound 4 lay 1.1-fold (0.03 log units) below the measured number, within the range that was stated.
By their numbers in this assay, from the lowest: compounds 4 and 3 (each within the scatter of the next); then compounds 1 and 2 (each within the scatter of the next).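

Among these compounds, this is the first step that isolates a single change at this position: in this assay, 4-chlorophenyl in place of 3-fluorophenyl gives a 1.1-fold lower number from compound 3 to compound 4 (0.06 log units; within the scatter), so the two compounds cannot be told apart here. The halogen and its place on the ring change together, so this one step cannot separate the two. No separate measurement bears on why these two groups read alike. Still open, from the compounds shown here alone, is whether a phenyl ring carrying an amine or a carboxylic acid here would read the same.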